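Working notes: from thiophene to thiazole on the carbonyl

A few compounds are considered here, and "the series" means these few. Any claim that something is new, unique, unknown or untested is made for them only; others in the source may bear on it.

Measured so far in a functional assay on BXPC-3 cells (Homo sapiens) for antiproliferative activity, read by sulforhodamine B assay, with a stated time of 72 h; on this read-out higher numbers stand for weaker inhibition and lower numbers for stronger inhibition:
- Compound 1 `CC(C)(C)c1[nH]cnc1/C=c1\[nH]c(=O)/c(=C/c2cccc(C(=O)N3CCCC3)c2)[nH]c1=O`: 325 nM
- Compound 2 `CC(C)(C)c1[nH]cnc1/C=c1\[nH]c(=O)/c(=C/c2cccc(C(=O)c3ccsc3)c2)[nH]c1=O`: 1.56 nM

Of the two measured compounds, compound 2 has the lower number at 1.56 nM, and compound 1 has the higher number at 325 nM.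

Compound 3 `CC(C)(C)c1[nH]cnc1/C=c1\[nH]c(=O)/c(=C/c2cccc(C(=O)c3cncs3)c2)[nH]c1=O` is next, with 1,3-thiazol-5-yl in place of thiophen-3-yl on a carbonyl carbon. The core and the rest of compound 2 stay unchanged.

Within the data shown here, only one measured step bears on this change: a 210-fold lower number from compound 1 to compound 2 (2.32 log units; beyond the scatter). It is large and beyond the scatter, and it arises at the same carbonyl carbon, which shows that the number in this assay can respond strongly to the group placed there. Among the measured compounds shown here, that step replaces pyrrolidin-1-yl, however, and no measured pair exchanges one five-membered aromatic ring for another, so its size does not carry over directly.

A much smaller change is expected here, most likely towards a higher number, and it may stay within the scatter. The expected step is a 2.6-fold higher number from compound 2 to compound 3 (0.41 log units; beyond the scatter). Compound 3 is estimated at 4 nM, with an expected range of 1.2 nM to 15 nM.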

Compound 3, half-maximal inhibitory concentration: 17.1 nM
For compound 3 the middle estimate is 4.3-fold (0.63 log units) below the measured one; measured number above the stated range.
By their numbers in this assay, from the lowest: compound 2; then compound 3; then compound 1.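

In this assay, exchanging one five-membered aromatic ring for another on the carbonyl carbon is not a minor edit: the step to 1,3-thiazol-5-yl gives an 11-fold higher number from compound 2 to compound 3 (1.04 log units; beyond the scatter), although the two rings have the same heavy-atom count and differ in carbon, nitrogen and hetero-atom count. The position therefore responds not only to the amide-to-ketone kind of change seen with pyrrolidin-1-yl, but also to the make-up of the aromatic ring itself, while 1,3-thiazol-5-yl still retains part of the advantage over pyrrolidin-1-yl, with a 19-fold lower number from compound 1 to compound 3 (1.28 log units; beyond the scatter). No measurement available here accounts for the loss from thiophen-3-yl to 1,3-thiazol-5-yl.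

The compounds shown leave open whether this loss follows the ring nitrogen as such or the particular 1,3-thiazol-5-yl arrangement, a question that 1,3-thiazol-2-yl, 1,3-thiazol-4-yl or furan-3-yl on the same carbonyl carbon could help to separate. They also leave open how a plain phenyl ring would compare with the two sulfur-containing rings, and whether an open-chain dimethylamino group would behave like pyrrolidin-1-yl.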